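Replacing Fluoro with Hydrogen in Compound 2

The compounds below may be only part of what the source reports. "The series", "measured", "known", "first", "only" and "open" are said of these compounds alone.

In a functional assay on A549 cells (Homo sapiens) for cytotoxicity, read by MTT assay, with a stated time of 48 h (on this read-out lower numbers stand for stronger inhibition and higher numbers for weaker inhibition), compound 1 (`COc1cc(-c2cc(COCc3cn(Cc4cc(C)cnc4Cl)nn3)on2)cc(OC)c1OC`) gives 256000 nM. Compound 2 (`COc1cc(COCc2cn(Cc3cc(-c4ccc(F)cc4)cnc3Cl)nn2)cc(OC)c1OC`) gives 50600 nM, the lower of the two numbers, and the gap between them lies beyond the usual scatter. These two compounds differ in more than one place, so their values cannot be tied to any single group. Compound 3 (`COc1cc(COCc2cn(Cc3cc(-c4ccccc4)cnc3Cl)nn2)cc(OC)c1OC`) departs from compound 2 by one change, hydrogen in place of fluoro on an aromatic carbon, or 4-fluorophenyl to phenyl. Among the measured compounds shown here, no measured pair here isolates this change, so the expectation has little direct support. Only a small move towards a higher number is expected, an estimated step of a 1.2-fold higher number from compound 2 to compound 3 (0.07 log units; within the scatter), which would stay within the scatter. In this assay, the estimated value for compound 3 is 60000 nM, with an expected range from 25000 nM to 140000 nM.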

Compound 3, half-maximal inhibitory concentration: 62600 nM
The estimate for compound 3 lay 1.0-fold (0.02 log units) below the measured number, and the stated range covers the measured number.
By their numbers in this assay, from the lowest: compounds 2 and 3 (each within the scatter of the next); then compound 1.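

In this assay, hydrogen in place of fluoro on an aromatic carbon, para to a large group, gives a 1.2-fold higher number from compound 2 to compound 3 (0.09 log units; within the scatter). Among the compounds shown here, this is the first comparison here that differs in one place, and it shows that the fluoro group can be exchanged for hydrogen at this position with no change beyond the scatter, so compound 3 holds the same level as compound 2 and the 4-fluorophenyl to phenyl change has no readable effect in this assay. No measurement is at hand that would explain this result.

The compounds shown leave open whether an amine or a carboxylic acid on the same aromatic carbon would also stay within the scatter of compound 3. They also leave the gap to compound 1 untied to any single group, since compound 1 differs from both in more than one place.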